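The compounds below may be only part of what the source reports. "The series", "measured", "known", "first", "only" and "open" are said of these compounds alone.

Measured compounds in an assay on Sf9 cells for inhibition of histone-lysine N-methyltransferase EZH2 (Homo sapiens), read by scintillation counting, with a stated time of 60 min, in the presence of a further agent that is not named here; on this read-out lower numbers stand for stronger inhibition and higher numbers for weaker inhibition: compound 1 `Cc1cc(C)c(CN2CCc3ccc(O[C@@H]4CCOC4)c(Cl)c3C2=O)c(=O)[nH]1` gives 28 nM; compound 2 `Cc1cc(C)c(CN2CCc3c(F)cc(O[C@@H]4CCOC4)c(Cl)c3C2=O)c(=O)[nH]1` gives 56 nM; compound 3 `Cc1cc(C)c(CN2CCc3ccc(OC(C)C)cc3C2=O)c(=O)[nH]1` gives 8100 nM.

Compound 3 stands at the highest number of the three, and its distance from compound 2, the nearest, and from compound 1, the furthest, lies well beyond the scatter in this assay. Compound 4 `Cc1cc(C)c(CN2CCc3ccc(OC(C)C)c(Cl)c3C2=O)c(=O)[nH]1` differs from compound 3 in one place: chloro in place of hydrogen on an aromatic carbon. Among the compounds with values here, no measured step matches this change. Within the data shown here, the only measured step, a 2.0-fold higher number from compound 1 to compound 2 (0.30 log units; within the scatter), concerns a different halogen at a different aromatic carbon and is within the scatter, so it gives little guidance. Compound 1 and compound 2 both carry the chloro group that compound 4 gains, but they also differ from compound 3 in their ether group, so their much lower numbers cannot be assigned to the chloro alone. On that basis a sizeable drop in number is expected for compound 4, a 20-fold lower number from compound 3 to compound 4 (1.31 log units; beyond the scatter), with wide uncertainty. Compound 4 is estimated at 400 nM, between 80 nM and 2000 nM.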

Compound 4, half-maximal inhibitory concentration: 41 nM
Beside the measured number, compound 4's estimate is 9.8-fold (0.99 log units) above it, and the stated range ends above it.
By their numbers in this assay, from the lowest: compounds 1, 4 and 2 (each within the scatter of the next); then compound 3.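

In this assay, the chloro group, placed on an aromatic carbon ortho to an isopropoxy group, accounts for a gap that the earlier compounds could not assign, with a 200-fold lower number from compound 3 to compound 4 (2.30 log units; beyond the scatter) as the step. The ether group could now be read apart from the chloro: with the chloro present, a 1.5-fold higher number from compound 1 to compound 4 (0.17 log units; within the scatter) is the step for isopropyl in place of oxolan-3-yl, so among these compounds the high number of compound 3 goes with the lack of chloro and not with its isopropoxy group. No measurement shown here offers an explanation for the size of the chloro step.

From the compounds shown here alone, the chloro step is read on the isopropoxy compounds alone, so its size with an oxolan-3-yl ether remains open. The compounds shown also leave open whether bromo, methyl or a nitrile on the same carbon would give a number like that of the chloro.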